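From 1,3-thiazol-2-yl to carbamoyl on the shared core

The compounds below may be only part of what the source reports. "The series", "measured", "known", "first", "only" and "open" are said of these compounds alone.

- compound 1 `N#Cc1c(Nc2ccccc2)nc(SCc2nc3ccccc3[nH]2)nc1-c1ccccc1`: 8.9 nM
- compound 2 `N#Cc1c(Nc2nccs2)nc(SCc2nc3ccccc3[nH]2)nc1-c1ccccc1`: 8.9 nM

Both compounds were tested in a functional assay on SK-MEL-28 cells (Homo sapiens) for cytotoxicity, read by MTT assay, with a stated time of 3 days (a higher number here means a weaker inhibitor, a lower number a stronger inhibitor), and compound 2 stands level with compound 1 at the digits given. The next compound to be tested is compound 3 `N#Cc1c(NC(N)=O)nc(SCc2nc3ccccc3[nH]2)nc1-c1ccccc1`. It carries carbamoyl in place of 1,3-thiazol-2-yl on a nitrogen on an aromatic ring. Cut one bond further out, the same difference reads (1,3-thiazol-2-yl)amino to ureido.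

Among the measured compounds shown here, only one measured step bears on this place. The step of no change at the digits printed from compound 1 to compound 2 (within the scatter) put 1,3-thiazol-2-yl in place of phenyl, and it stayed within the scatter. For the measured compounds named here, that step exchanged one ring for another, whereas carbamoyl brings no ring, and no measured compound shows what happens here without one. The evidence is therefore thin, and a small move toward weaker inhibition in this assay is expected, with wide uncertainty. The expected step is a 1.7-fold higher number from compound 2 to compound 3 (0.23 log units; within the scatter). For compound 3 the estimated value is 15 nM (4 nM to 60 nM).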

Compound 3, half-maximal inhibitory concentration: 4.8 nM
The estimate for compound 3 lay 3.1-fold (0.49 log units) above the measured number, within the range that was stated.
By their numbers in this assay, from the lowest: compounds 3, 1 and 2 (each within the scatter of the next).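

Carbamoyl on a nitrogen on an aromatic ring brings no ring, yet in this assay the change gives a 1.9-fold lower number from compound 2 to compound 3 (0.27 log units; within the scatter), and the comparison with phenyl as the departing group gives a 1.9-fold lower number from compound 1 to compound 3 (0.27 log units; within the scatter). The earlier step exchanged one ring for another, so only now is it visible that, among these three compounds, a ring at this place is not required for a number in this range. The same holds for a group that brings a hydrogen-bond donor, which neither phenyl nor 1,3-thiazol-2-yl has, but nothing available here gives a reason why the numbers stay within the scatter across these groups.

The compounds shown leave open how far this tolerance extends, for instance whether a plain amine in place of the ureido, or a longer chain on that nitrogen, would also stay within the scatter. They also leave open whether the same holds outside this assay, since all three values come from that single cell-based test.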